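Amino for Nitro on the Benzylic Ring of Compound 2

The source may report more compounds than this note shows. Statements on the series, on what has been measured and on what is new or still open speak of the compounds shown alone.

The three measured compounds share a styryl sulfone core. Compound 1 `COc1cc(OC)c(/C=C/S(=O)(=O)Cc2ccc(OC)c(N)c2)c(OC)c1` carries an amino group and in a functional assay on MCF7 cells (Homo sapiens) for cytotoxicity, read by MTT assay, with a stated time of 72 h (a lower number here means a stronger inhibitor of growth, a higher number a weaker inhibitor of growth), compound 1 gives < 10 nM, which is a limit of the assay and not a number. Compound 3 `COc1cc(/C=C/S(=O)(=O)Cc2ccc(OC)c([N+](=O)[O-])c2)cc(OC)c1` carries a nitro group, and in this assay compound 3 gives > 30000 nM, again a limit. Compound 2 `COc1ccc(CS(=O)(=O)/C=C/c2ccc(OC)c(OC)c2OC)cc1[N+](=O)[O-]` also carries a nitro group; in this assay compound 2 gives > 30000 nM, once more a limit rather than a number. Compound 2 therefore stands at the weak end of what is shown, sharing the limit of > 30000 nM in this assay, at which 2 of the 3 values shown sit, with compound 3, while only compound 1 sits at the limit of < 10 nM in this assay, at which 1 of the 3 values shown sits.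

Compound 4 `COc1ccc(CS(=O)(=O)/C=C/c2ccc(OC)c(OC)c2OC)cc1N` differs from compound 2 by amino in place of nitro on an aromatic carbon. Going by the values given here, no step between measured compounds isolates this change, yet the amino-bearing compound 1 and the nitro-bearing compounds 2 and 3 lie at opposite limits. A large step toward stronger growth inhibition is expected, though compound 4 keeps the methoxy pattern of compound 2 rather than that of compound 1, so the gain is uncertain. Compound 4 is estimated at 300 nM, between 5 nM and 20000 nM, a step of an at least 100-fold lower number from compound 2 to compound 4 (2.00 log units; beyond the scatter) expected.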

Compound 4, concentration for 50% growth inhibition: 5950 nM
Estimate against measurement, compound 4: 20-fold (1.30 log units) below; low and high end bracket the measured number.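

In this assay, going by these compounds alone, amino in place of nitro on this aromatic carbon, ortho to a methoxy group, gives the first readable step at this position, which is an at least 5.0-fold lower number from compound 2 to compound 4 (0.70 log units; beyond the scatter). Compound 4 gives 5950 nM, an actual number rather than a limit, so this change on the methoxy pattern of compound 2 brings the read-out within the range of the assay and shows that the amino group can be measured here on its own terms. The true size of the step remains unknown and only its lower bound can be read, because compound 2 stands at a limit of the assay: the limit of > 30000 nM in this assay, at which 2 of the 4 values shown sit.

Compound 1 gives < 10 nM, which is a limit of the assay, and it carries a different methoxy pattern, so the compounds shown leave open how far that pattern, rather than the amino group, decides the read-out. Also open, from the compounds shown here alone, is whether another group on this aromatic carbon, such as a hydroxyl group, an acetamide or a dimethylamino group, would give a lower or a higher number than amino does on the core of compound 4.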